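Bromo in Place of Chloro: From Compound 1 to Compound 3

The source may report more compounds than this note shows. Statements on the series, on what has been measured and on what is new or still open speak of the compounds shown alone.

Compound 1 `O=C(N/N=C/c1ccc(Cl)cc1)c1cnccn1` was tested in an ADME assay on J774 cells (Mus musculus) for cytotoxicity, read by MTT assay, with a stated time of 48 h, tested at 100 ug/mL; a lower number here means a stronger effect, a higher number a weaker effect of the compound at the concentration tested. For the measured compounds named here, there compound 1 gives 64%, the higher of the two numbers known so far. Compound 2 `O=C(N/N=C/c1cccc(F)c1)c1cnccn1` gives 46% in this assay, a gap beyond the usual scatter. Compound 3 `O=C(N/N=C/c1ccc(Br)cc1)c1cnccn1` has not yet been measured. Its structure differs from compound 1 by bromo in place of chloro on an aromatic carbon. Going by the values given here, no measured pair shows this change on its own, so only a small step is expected, within the scatter or barely beyond it: a number 4 percentage points lower from compound 1 to compound 3 (within the scatter). Compound 3 is expected to give about 60%, in a range from 42% to 78%.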

Compound 3, a percentage reported as activity, at one concentration (the size of the read-out at that concentration, not a potency): 100%
Compound 3: the middle estimate sits 40 percentage points below what was measured; the measured number lies above the stated range.
By their numbers in this assay, from the lowest: compound 2; then compound 1; then compound 3.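

In this assay, bromo in place of chloro on this aromatic carbon gives a number 36 percentage points higher from compound 1 to compound 3 (beyond the scatter), so exchanging one halogen for another at this position can be a large change. Since a higher number means a weaker effect, compound 3 acts more weakly on these cells than compound 1 does. Nothing measured here explains why one atom matters this much. The compounds shown leave open how an amine or a carboxylic acid on this same carbon would read, and whether iodo would go further in the same direction.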